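A few compounds are considered here, and "the series" means these few. Any claim that something is new, unique, unknown or untested is made for them only; others in the source may bear on it.

Compound 1 `COc1cc(-c2nc3ccccc3s2)ccc1OCC(=O)NNC(=O)CCl` and compound 2 `COc1cc(-c2nc3ccccc3s2)ccc1OCC(=O)NNC(=O)CN(C(C)=O)[C@@H](CS)C(=O)O` share one core. Among the measured compounds shown here, in a functional assay on MCF7 cells (Homo sapiens) for inhibition, read by MTT assay, with a stated time of 3 days (on this read-out lower numbers stand for stronger inhibition and higher numbers for weaker inhibition), compound 1 gives 780 nM, the lowest of the two numbers measured so far; compound 2 gives 1750 nM. For the measured compounds named here, the single measured step, a 2.2-fold higher number from compound 1 to compound 2 (0.35 log units; beyond the scatter), is modest yet beyond the scatter.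

Compound 3 `CCOC(=O)[C@H](CS)N(CC(=O)NNC(=O)COc1ccc(-c2nc3ccccc3s2)cc1OC)C(C)=O` differs from compound 1 by acetyl(1-(ethoxycarbonyl)-2-sulfanylethyl)amino in place of chloro on a saturated chain carbon bound to a carbonyl carbon. Going by the values given here, this exchange parallels the one leading to compound 2, the entering group carrying an ethoxycarbonyl where the group in compound 2 carries a carboxy, so the step to compound 2 is the only comparison that bears on it. Since compound 2 moved by a 2.2-fold higher number from compound 1 to compound 2 (0.35 log units; beyond the scatter) on that closely related exchange, a step of similar size and direction is expected for compound 3, namely a 2.1-fold higher number from compound 1 to compound 3 (0.31 log units; beyond the scatter). Compound 3 is accordingly estimated at 1600 nM, with a range from 700 nM to 3600 nM.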

Compound 3, half-maximal inhibitory concentration: 1890 nM
For compound 3 the middle estimate is 1.2-fold (0.07 log units) below the measured one; measured number inside the range.
By their numbers in this assay, from the lowest: compound 1; then compounds 2 and 3 (each within the scatter of the next).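

In this assay, the step with acetyl(1-(ethoxycarbonyl)-2-sulfanylethyl)amino in place of chloro on this saturated chain carbon is a 2.4-fold higher number from compound 1 to compound 3 (0.38 log units; beyond the scatter), so a second entering group of this type also lies beyond the scatter from the chloro compound, in the same direction as compound 2. Ethyl in place of hydrogen on an oxygen next to a carbonyl group gives a 1.1-fold higher number from compound 2 to compound 3 (0.03 log units; within the scatter), so carboxy and ethoxycarbonyl cannot be told apart on this read-out in this pair. Nothing shown bears on the reason for either step.

Which part of the entering group accounts for the step from chloro remains open. A plain amine at this carbon, or a hydroxyl in place of the sulfanyl, would help to separate those parts.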